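The source may hold more compounds than are shown below. What is called first, only, known or untested is meant among the compounds shown, and "the series" means these compounds.

Measured so far:
- Compound 1 `CN[C@]1(C(=O)OC)C[C@H]2O[C@]1(C)n1c3ccccc3c3c4c(c5c6ccccc6n2c5c31)C(=O)NC4`: > 2500 nM
- Compound 2 `CO[C@@H]1[C@H](NC(=O)C(=O)c2c[nH]c3ccccc23)C[C@H]2O[C@]1(C)n1c3ccccc3c3c4c(c5c6ccccc6n2c5c31)C(=O)NC4`: 1790 nM

In an assay on isolated protein for inhibition of protein kinase C theta type (Homo sapiens), read by HTRF (on this read-out higher numbers stand for weaker inhibition and lower numbers for stronger inhibition), compound 1 reaches only a limit, > 2500 nM. In this assay, among the compounds with values here, compound 2 gives 1790 nM, the single number in the set. Of the two entries, one is the limit of > 2500 nM in this assay, at which 1 of the 2 values shown sits.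

Compound 3 `CO[C@@H]1[C@H](NC=O)C[C@H]2O[C@]1(C)n1c3ccccc3c3c4c(c5c6ccccc6n2c5c31)C(=O)NC4` differs from compound 2 by hydrogen in place of (1H-indol-3-yl)carbonyl on a carbonyl carbon. Within the data shown here, no measured pair covers such a change, so the expectation rests on compound 2 alone. The expected step is a 2.2-fold higher number from compound 2 to compound 3 (0.35 log units; beyond the scatter), a weakening beyond the scatter. Compound 3 is estimated at 4000 nM, within 1300 nM to 12000 nM, with a fair chance that only a limit is returned.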

Compound 3, half-maximal inhibitory concentration: > 2500 nM
Compound 3 gave a limit, no number (the forecaster's own chance of this, stated with the estimate: 55%); the middle value lies beyond the limit too.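

Hydrogen in place of (1H-indol-3-yl)carbonyl on a carbonyl carbon gives the one single-place comparison in the series: an at least 1.3-fold higher number from compound 2 to compound 3 (0.14 log units; that floor lies within the scatter). In this assay compound 3 gives > 2500 nM, which is a limit and not a number, and the floor of the step does not separate the pair. The true size of the step stays unknown because readings end at that limit: the limit of > 2500 nM in this assay, at which 2 of the 3 values shown sit.

Open, going by these compounds, is how much of the (1H-indol-3-yl)carbonyl is needed for a number to be read at all. Methyl or phenyl on that carbonyl carbon would test this.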